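The source may report more compounds than this note shows. Statements on the series, on what has been measured and on what is new or still open speak of the compounds shown alone.

Compound 1 `CCCOc1ccc2c(N3CCNCC3)cc(=O)oc2c1C`: 2950 nM
Compound 2 `CSCOc1ccc2c(N3CCNCC3)cc(=O)oc2c1C`: 900 nM
Compound 3 `Cc1c(OCC2CCCN(C)C2)ccc2c(N3CCNCC3)cc(=O)oc12`: 4700 nM
Compound 4 `Cc1c(OCCOc2ccccc2)ccc2c(N3CCNCC3)cc(=O)oc12`: not yet measured

All values come from a functional assay on a cell-free system (plasma, Homo sapiens) for inhibition, with Plasma (Rattus norvegicus) as the target; a higher number here means a weaker inhibitor, a lower number a stronger inhibitor. The high end of the numbers holds compound 3 at 4700 nM: a 1.6-fold higher number from compound 1 to compound 3 (0.20 log units; within the scatter), but a 5.2-fold higher number from compound 2 to compound 3 (0.72 log units; beyond the scatter).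

The next change is phenoxymethyl in place of 1-methylpiperidin-3-yl on a saturated chain carbon bound to an oxygen on an aromatic ring. Among the compounds with values here, no measured compound carries an aromatic ring in this group, so only the general size of steps at this place can guide. Besides those above, the remaining step there is a 3.3-fold lower number from compound 1 to compound 2 (0.52 log units; beyond the scatter). All stay modest or smaller, so no shift beyond the scatter is expected in this assay.

The expected step is a 1.9-fold lower number from compound 3 to compound 4 (0.27 log units; within the scatter). For compound 4 the estimated value is 2500 nM, within an expected range of 800 nM to 7500 nM.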

Compound 4, half-maximal inhibitory concentration: 9400 nM
Compound 4: the middle estimate sits 3.8-fold (0.58 log units) below what was measured, outside the stated range (above it).
By their numbers in this assay, from the lowest: compound 2; then compounds 1, 3 and 4 (each within the scatter of the next, the first and the last beyond it).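

At this place, on a saturated chain carbon bound to an oxygen on an aromatic ring, phenoxymethyl brings the first aromatic ring into the group, and in this assay it gives a 2.0-fold higher number from compound 3 to compound 4 (0.30 log units; within the scatter), so it cannot be told apart from 1-methylpiperidin-3-yl. Against the two remaining groups it does separate, with a 3.2-fold higher number from compound 1 to compound 4 (0.50 log units; beyond the scatter) and a 10-fold higher number from compound 2 to compound 4 (1.02 log units; beyond the scatter), leaving compound 2 the strongest of the four. From the compounds shown here alone, whether the sulfur of methylsulfanyl matters remains open, and a methoxymethyl group at this place would test that. No available evidence accounts for these steps.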